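From 2-methylbenzyl to 4-methoxybenzyl: an expected step

The source may report more compounds than this note shows. Statements on the series, on what has been measured and on what is new or still open speak of the compounds shown alone.

Compound 1 `COc1cccc(OC)c1OCCNCCOc1ccccc1OCc1ccccc1C` and compound 2 `COc1cccc(OC)c1OCCNCCOc1ccccc1OCc1ccccc1[N+](=O)[O-]` share one core and differ only at the benzyl ring. In a functional assay on spleen for antagonist activity at Alpha-1B adrenergic receptor (Rattus norvegicus) (a lower number here means a less potent compound, a higher number a more potent compound, by a factor of ten per unit of this negative logarithm), compound 1 gives 7.67, while compound 2 gives 8.56. For the measured compounds named here, of these two numbers, compound 1 stands lowest, with compound 2 as its only neighbour, and the single recorded step, a number 0.89 log units higher from compound 1 to compound 2 (beyond the scatter), shows what a change on this ring can do. Compound 3 `COc1ccc(COc2ccccc2OCCNCCOc2c(OC)cccc2OC)cc1` has not yet been measured. It differs from compound 1 by 4-methoxyphenyl in place of 2-methylphenyl on a saturated chain carbon bound to an oxygen on an aromatic ring. Going by the values given here, the step from compound 1 to compound 2 bears on this only loosely: it concerns the same ring, but a different group at a different place, and no measured pair shows the present swap itself. A step of modest size, or none beyond the scatter, is therefore expected. The estimate leans to a small gain, a number 0.23 log units higher from compound 1 to compound 3 (within the scatter). Compound 3 is thus expected to give about 7.9, within 7.2 to 8.6.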

Compound 3, negative logarithm of the antagonist equilibrium constant: 9.51
Compound 3: the middle estimate sits 1.61 log units below what was measured; the measured number lies above the stated range.
By their numbers in this assay, from the lowest: compound 1; then compound 2; then compound 3.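

In this assay the change from 2-methylphenyl to 4-methoxyphenyl brings a number 1.84 log units higher from compound 1 to compound 3 (beyond the scatter) and the change from 2-nitrophenyl to 4-methoxyphenyl brings a number 0.95 log units higher from compound 2 to compound 3 (beyond the scatter) on the same saturated chain carbon bound to an oxygen on an aromatic ring. This position can therefore carry a larger gain than the earlier nitro step had shown, and compound 3 stands above both compound 1 and compound 2. No measurement given here accounts for this gain.

The swap from compound 1 to compound 3 alters both the group on the ring and its place, so the compounds shown do not separate the methoxy group from its location. Also open, as far as these compounds go, is how a hydroxyl or an amine in place of that methoxy group would read in this assay.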